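Replacing the side chain of compound 3

A few compounds are considered here, and "the series" means these few. Any claim that something is new, unique, unknown or untested is made for them only; others in the source may bear on it.

In an ADME assay on TZM cells (Homo sapiens) for cytotoxicity, read by XTT assay, with a stated time of 4 days (a higher number here means that more compound is tolerated, a lower number that less compound is tolerated), three compounds on a shared core have been measured. Compound 1 (`Cc1cc(Br)cc(C)c1Oc1ccc(N)c(Nc2ccc(C#N)cc2)n1`) gives 15500 nM, compound 2 (`C=CCc1cc(C)c(Oc2ccc(N)c(Nc3ccc(C#N)cc3)n2)c(C)c1`) gives 8460 nM, and compound 3 (`Cc1cc(/C=C/C(=O)O)cc(C)c1Oc1ccc(N)c(Nc2ccc(C#N)cc2)n1`) gives 18000 nM. Compound 3 stands within the scatter of the bromo compound, a 1.2-fold higher number from compound 1 to compound 3 (0.06 log units; within the scatter), and just clear of the allyl compound, a 2.1-fold higher number from compound 2 to compound 3 (0.33 log units; beyond the scatter).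

Compound 4 (`CC(=O)CCc1cc(C)c(Oc2ccc(N)c(Nc3ccc(C#N)cc3)n2)c(C)c1`) carries 2-acetylethyl in place of 2-carboxyethenyl on an aromatic carbon. Among the compounds with values here, no measured compound carries this group, so the only guide is the three swaps at the same carbon. Besides the two steps above, the third is a 1.8-fold lower number from compound 1 to compound 2 (0.26 log units; within the scatter). The largest of these is only modest, and the values of compounds 1 to 3 lie close together. No step beyond the scatter is therefore expected, only a slight lean downward, estimated as a 1.6-fold lower number from compound 3 to compound 4 (0.21 log units; within the scatter). The estimate for compound 4 is 11000 nM, with an expected range of 5000 nM to 22000 nM.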

Compound 4, half-maximal cytotoxic concentration: 9250 nM
Compound 4: the middle estimate sits 1.2-fold (0.08 log units) above what was measured; low and high end bracket the measured number.
By their numbers in this assay, from the lowest: compounds 2, 4, 1 and 3 (each within the scatter of the next, the first and the last beyond it).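

In this assay, the exchange of 2-carboxyethenyl for 2-acetylethyl gives a step within the scatter (a 1.9-fold lower number from compound 3 to compound 4 (0.29 log units; within the scatter)), so removing the hydrogen-bond donor and one double bond outside the aromatic rings produces no readable change at this carbon. The other two steps also stay within the scatter (a 1.1-fold higher number from compound 2 to compound 4 (0.04 log units; within the scatter); a 1.7-fold lower number from compound 1 to compound 4 (0.22 log units; within the scatter)). Compound 4 therefore lies within the scatter of all three earlier compounds, and the series now shows four different groups at this position, spanning a narrow range of values.

No measurement bears on the cause of these small differences. Going by these compounds, whether an amine, a ring or a chain longer than 2-acetylethyl at this carbon would give a step beyond the scatter remains open.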